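The compounds below may be only part of what the source reports. "The series", "measured", "known", "first", "only" and "open" are said of these compounds alone.

Compound 1 `NC1CCC(Nc2nc(NCc3ccc(-c4ccccc4)cc3)c3ncn(C4CCCC4)c3n2)CC1` gives 290 nM
Compound 2 `NC1CCC(Nc2nc(NCc3ccc(-c4ccco4)cc3)c3ncn(C4CCCC4)c3n2)CC1` gives 102 nM
Compound 3 `NC1CCC(Nc2nc(NCc3ccc(-c4ccco4)nc3)c3ncn(C4CCCC4)c3n2)CC1` has not yet been measured

Going by the values given here, in a functional assay on HOS cells (Homo sapiens) for inhibition, with a stated time of 72 h (on this read-out higher numbers stand for weaker inhibition and lower numbers for stronger inhibition), compound 1 stands at 290 nM as the higher of the two numbers so far, which makes it the weaker inhibitor of the measured pair. The move to compound 3 exchanges one group on a saturated chain carbon bound to a nitrogen on an aromatic ring, with 6-(furan-2-yl)pyridin-3-yl in place of 4-phenylphenyl (6-(furan-2-yl)pyridin-3-yl in place of 4-phenylphenyl on a saturated chain carbon bound to a nitrogen on an aromatic ring). Among the compounds with values here, one measured step bears on this: a 2.8-fold lower number from compound 1 to compound 2 (0.45 log units; beyond the scatter) came with furan-2-yl in place of phenyl on an aromatic carbon, a modest change. Within the data shown here, compound 3 carries the same furan-2-yl, but its six-membered aromatic ring also has 1 hetero atom, and no measured step shows that second change alone. A step of similar size toward lower numbers is therefore expected, with added uncertainty. The estimated step is a 2.2-fold lower number from compound 1 to compound 3 (0.35 log units; beyond the scatter) in this reading. In this assay compound 3 is expected at 130 nM (estimated range 45 nM to 380 nM).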

Compound 3, half-maximal inhibitory concentration: 44 nM
Beside the measured number, compound 3's estimate is 3.0-fold (0.47 log units) above it; the measured number lies below the stated range.
By their numbers in this assay, from the lowest: compound 3; then compound 2; then compound 1.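

In this assay, the step of a 2.3-fold lower number from compound 2 to compound 3 (0.37 log units; beyond the scatter) shows what the first two compounds could not: with the furan-2-yl kept in both, exchanging 4-(furan-2-yl)phenyl for 6-(furan-2-yl)pyridin-3-yl, whose six-membered aromatic ring holds 1 hetero atom (a ring atom other than carbon, here nitrogen), strengthens inhibition on its own. The whole exchange of 4-phenylphenyl for 6-(furan-2-yl)pyridin-3-yl gives a 6.6-fold lower number from compound 1 to compound 3 (0.82 log units; beyond the scatter), a larger step than a 2.8-fold lower number from compound 1 to compound 2 (0.45 log units; beyond the scatter), so among these three compounds both the furan-2-yl and the ring nitrogen go with lower numbers at this position, and no compound goes against that. No measurement at hand explains why the ring nitrogen lowers the number.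

On these data alone, whether the same ring nitrogen would help with a plain outer ring, as in a 6-phenylpyridin-3-yl group, stays open. As far as these compounds go, it is equally open how a thiophen-2-yl group in place of the furan-2-yl, or a carboxylic acid on the outer ring, would read in this assay.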